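Methylpiperazine dithiocarbamate benzamide: expected effect on cell growth

The source may report more compounds than this note shows. Statements on the series, on what has been measured and on what is new or still open speak of the compounds shown alone.

Compound 1: `CCN(Cc1ccncc1)C(=S)SCc1ccc(C(=O)Nc2ccccc2N)cc1`, 86.2%
Compound 2: `Nc1ccccc1NC(=O)c1ccc(CSC(=S)N2CCN(c3ccccc3F)CC2)cc1`, 79.5%
Compound 3: `Nc1ccccc1NC(=O)c1ccc(CSC(=S)N2CCN(c3cccnc3)CC2)cc1`, 88.8%

In a functional assay on A-375 cells (Homo sapiens) for antiproliferative activity, read by CCK-8 assay, with a stated time of 72 h, tested at 8 uM (a higher number here means a stronger effect of the compound at the concentration tested, a lower number a weaker effect), compound 3 gives the highest of the three numbers, yet its gaps to compound 1 and to compound 2 both lie within the scatter, so no order among them can be claimed. For the measured compounds named here, the only measured step bearing on the change at the ring nitrogen is a number 9.3 percentage points higher from compound 2 to compound 3 (within the scatter), which exchanges one aromatic group for another on that nitrogen and stays within the scatter.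

Compound 4, `CN1CCN(C(=S)SCc2ccc(C(=O)Nc3ccccc3N)cc2)CC1`, differs from compound 3 by methyl in place of pyridin-3-yl on an amine nitrogen in a ring. No measured pair shows a methyl on that ring nitrogen, so the step from compound 3 to compound 4 is not covered by the shown data. Since the aromatic-for-aromatic swap in this assay moved little, compound 4 is expected to keep a substantial effect, but with a loss of size allowed for: the expected step is a number 14.8 percentage points lower from compound 3 to compound 4 (beyond the scatter). Compound 4 is therefore estimated at 74%, within a range from 50% to 92%.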

Compound 4, a percentage reported as inhibition, at one concentration (the size of the read-out at that concentration, not a potency): 91.6%
Compound 4: middle estimate off by 17.6 percentage points, on the low side; the range from low to high includes it.
By their numbers in this assay, from the lowest: compounds 2, 1, 3 and 4 (each within the scatter of the next, the first and the last beyond it).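

Within this assay, the step of a number 2.8 percentage points higher from compound 3 to compound 4 (within the scatter) shows that, on this amine nitrogen in a ring, a lone methyl serves as well as pyridin-3-yl, so an aromatic ring at this position is not required for a large read-out. Against 2-fluorophenyl, the same methyl gives a number 12.1 percentage points higher from compound 2 to compound 4 (beyond the scatter), the only one of these steps beyond the scatter, and a modest one. Placing 4-methylpiperazin-1-yl in place of ethyl((pyridin-4-yl)methyl)amino on the thiocarbonyl carbon gives a number 5.4 percentage points higher from compound 1 to compound 4 (within the scatter), so these two amine parts cannot be told apart here.

What the compounds shown leave open is how a longer chain, such as propyl, or a chain ending in a carboxylic acid would fare on this ring nitrogen. Nothing shown gives a reason for any of these steps.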